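The compounds below may be only part of what the source reports. "The series", "measured", "known", "first", "only" and "open" are said of these compounds alone.

Of the compounds shown here, two have been measured in a functional assay on SK-MEL-2 cells (Homo sapiens) for cytotoxicity, read by sulforhodamine B assay, with a stated time of 48 h, tested at 0.01 uM; a higher number here means a weaker effect of the compound at the concentration tested, a lower number a stronger effect. Compound 1 `Cc1cc(O)cc(-c2nn(CC#N)cc2-c2ccnc(-c3ccc(Oc4ccccc4)cc3)c2)c1` gives 99% in this assay. Compound 2 `COc1cc(C)cc(-c2nn(CC#N)cc2-c2ccnc(-c3ccc(N(C)C)cc3)c2)c1` gives 116% in this assay, the highest of the two numbers, and its nearest neighbour, compound 1, sits a step below it that lies beyond the usual scatter. Compound 3 `Cc1cc(O)cc(-c2nn(CC#N)cc2-c2ccnc(-c3ccc(N(C)C)cc3)c2)c1` has not yet been tested. It differs from compound 2 in one place: hydrogen in place of methyl on an oxygen on an aromatic ring. Compound 3 thereby carries the same 3-hydroxy-5-methylphenyl as compound 1, so both measured compounds bear on it. Since compound 2 at 116% and compound 1 at 99% both sit near the level of no effect at this concentration, only a small downward step, if any, is expected. The expected step of a number 13 percentage points lower from compound 2 to compound 3 (beyond the scatter) may well fall within the scatter. For compound 3 the expected value in this assay is 103%, within a range from 88% to 118%.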

Compound 3, a percentage reported as activity, at one concentration (the size of the read-out at that concentration, not a potency): 108%
Compound 3: middle estimate off by 5 percentage points, on the low side; low and high end bracket the measured number.
By their numbers in this assay, from the lowest: compounds 1, 3 and 2 (each within the scatter of the next, the first and the last beyond it).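

Methoxy to hydroxy on the aromatic ring reads in this assay as a number 8 percentage points lower from compound 2 to compound 3 (within the scatter) and so does not separate the two groups at this single concentration. Going by these compounds alone, compound 3 also gives the first direct comparison at the second place: dimethylamino in place of phenoxy on an aromatic carbon reads as a number 9 percentage points higher from compound 1 to compound 3 (within the scatter) and does not separate these two groups either. Nothing at hand explains either step.

All three compounds sit near the level of no effect at this concentration, so the series cannot yet show whether either place matters where the compounds act more strongly. As far as these compounds go, it also remains open whether ethoxy on that oxygen, or a morpholine or a carboxylic acid in place of dimethylamino, would move the read-out beyond the scatter.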